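Two Measured Compounds Point Toward a Third

This account rests on a few compounds, and the source may have more. Where it says the series, first, only, none or still open, it means among the compounds named here.

Of the compounds shown here, two sharing one core have been tested in a functional assay on DU-145 cells (Homo sapiens) for antiproliferative activity, read by MTT assay, with a stated time of 24 h; on this read-out lower numbers stand for stronger inhibition and higher numbers for weaker inhibition. Compound 1 `COc1ccc(-c2cc(/C=C/C(=O)c3cc(OC)c(OC)c(OC)c3)nc3cc(-c4ccccc4)nn23)cc1OC` carries a 3,4,5-trimethoxyphenyl on its carbonyl carbon, and in this assay compound 1 gives 8300 nM. Compound 2 `COc1ccc(-c2cc(/C=C/C(=O)c3ccc(Cl)cc3)nc3cc(-c4ccccc4)nn23)cc1OC` carries a 4-chlorophenyl there instead, and in this assay compound 2 gives 21300 nM. Among the measured compounds shown here, that single exchange gave a 2.6-fold higher number from compound 1 to compound 2 (0.41 log units; beyond the scatter), so compound 2 stands as the higher of the two numbers, with compound 1 the only neighbour available for comparison.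

Compound 3 `COc1ccc(-c2cc(C(=O)/C=C/c3ccccc3)nc3cc(-c4ccccc4)nn23)cc1OC` has not yet been measured. It differs from compound 2 by (2-phenylethenyl)carbonyl in place of 2-((4-chlorophenyl)carbonyl)ethenyl on an aromatic carbon. For the measured compounds named here, no measured step mirrors this change: the one step known concerns the aryl group on the carbonyl, not the order of the ethenyl and carbonyl pieces, and here the chlorine is lost rather than exchanged for another aryl group. Because a 2.6-fold higher number from compound 1 to compound 2 (0.41 log units; beyond the scatter) was modest, a step of similar or smaller size in either direction is plausible, and no direction can be asserted with confidence. The expected step is a 1.0-fold higher number from compound 2 to compound 3 (0.01 log units; within the scatter). Compound 3 is estimated at 22000 nM, with a range from 7000 nM to 70000 nM.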

Compound 3, half-maximal inhibitory concentration: 15600 nM
For compound 3 the middle estimate is 1.4-fold (0.15 log units) above the measured one; the measured number falls inside the stated range.
By their numbers in this assay, from the lowest: compounds 1, 3 and 2 (each within the scatter of the next, the first and the last beyond it).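

In this assay, placing (2-phenylethenyl)carbonyl in place of 2-((4-chlorophenyl)carbonyl)ethenyl on the aromatic carbon next to the ring nitrogen gives a 1.4-fold lower number from compound 2 to compound 3 (0.14 log units; within the scatter). This position therefore accepts a change larger than the earlier exchange of the aryl group on the carbonyl, since the carbonyl and ethenyl pieces swap their order and the chlorine goes, yet compound 2 and compound 3 cannot be told apart in this test. No measurement here explains why the two read so alike.

The swapped order and the lost chlorine arrive together in this one step, so the compounds shown do not reveal what each does alone, and the two might pull in opposite directions or have no effect at all. Also open, going by these compounds, is how this position would respond to an amine or a carboxylic acid on the phenyl ring of the (2-phenylethenyl)carbonyl group, or to a longer chain in place of the ethenyl piece.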